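Pivaloyl amide in place of fluorobenzoyl amide

The compounds below may be only part of what the source reports. "The series", "measured", "known", "first", "only" and "open" are said of these compounds alone.

Measured compounds:
compound 1 `[O-][S+](CCNC1CCN(Cc2ccc(F)cc2)CC1)C(c1ccc(F)cc1)c1ccc(F)cc1` — 26.5 nM
compound 2 `[O-][S+](CCNC1CCN(CC(O)Cc2ccccc2)CC1)C(c1ccc(F)cc1)c1ccc(F)cc1` — 351 nM
compound 3 `O=C(c1ccc(F)cc1)N1CCC(NCC[S+]([O-])C(c2ccc(F)cc2)c2ccc(F)cc2)CC1` — 1440 nM

In an assay on membranes from Cortex for displacement of a labelled ligand from Sigma non-opioid intracellular receptor 1 (Cavia porcellus), read by scintillation counting, with a stated time of 120 min (a higher number here means a weaker inhibitor, a lower number a stronger inhibitor), compound 3 gives the highest number of the three. The two changes leading to it were both sizeable: a 54-fold higher number from compound 1 to compound 3 (1.74 log units; beyond the scatter) and a 4.1-fold higher number from compound 2 to compound 3 (0.61 log units; beyond the scatter). Compound 4 `CC(C)(C)C(=O)N1CCC(NCC[S+]([O-])C(c2ccc(F)cc2)c2ccc(F)cc2)CC1` keeps that carbonyl on the ring nitrogen and alters only its substituent: tert-butyl in place of 4-fluorophenyl on a carbonyl carbon. Within the data shown here, no measured step exchanges an aromatic group for a tert-butyl group on this carbonyl carbon, so the comparison rests on compound 3 alone. Since the carbonyl on the ring nitrogen is retained, compound 4 is expected to stay near compound 3, with a modest shift toward a higher number, a 1.7-fold higher number from compound 3 to compound 4 (0.24 log units; within the scatter). Compound 4 is therefore estimated at 2500 nM, within 800 nM to 8000 nM.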

Compound 4, inhibition constant: 11200 nM
Compound 4: the middle estimate sits 4.5-fold (0.65 log units) below what was measured, outside the stated range (above it).
By their numbers in this assay, from the lowest: compound 1; then compound 2; then compound 3; then compound 4.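

In this assay the carbonyl alone does not set the level: tert-butyl in place of 4-fluorophenyl on the same carbonyl carbon gives a 7.8-fold higher number from compound 3 to compound 4 (0.89 log units; beyond the scatter) within one amide series. The distance to the compounds with no carbonyl on the ring nitrogen grows as well, with a 32-fold higher number from compound 2 to compound 4 (1.50 log units; beyond the scatter) and a 420-fold higher number from compound 1 to compound 4 (2.63 log units; beyond the scatter) on record. No measured evidence bearing on this change is available.

From the compounds shown here alone, whether an unsubstituted phenyl, a cyclohexyl group or a longer chain on that carbonyl carbon would stay near compound 3 remains open. So does whether the ring or the fluorine of 4-fluorophenyl accounts for the step.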